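Replacing the isopropylcarbamoyl of compound 2 with hydroxymethyl

This account rests on a few compounds, and the source may have more. Where it says the series, first, only, none or still open, it means among the compounds named here.

In a functional assay on cells (Platelet, Homo sapiens) for inhibition (a higher number here means a weaker inhibitor, a lower number a stronger inhibitor), compound 1 `COC(=O)c1ccc(-c2nn(Cc3ccccc3)c3ccccc23)cc1` gives 560 nM. Compound 2 `CC(C)NC(=O)c1ccc(-c2nn(Cc3ccccc3)c3ccccc23)cc1` reads > 10000 nM, which is a limit of the assay and not a number.

Compound 3 `OCc1ccc(-c2nn(Cc3ccccc3)c3ccccc23)cc1` keeps the shared core and has hydroxymethyl in place of isopropylcarbamoyl on an aromatic carbon, para to a large group: hydroxymethyl in place of isopropylcarbamoyl on an aromatic carbon.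

Going by the values given here, one measured step bears on this change: an at least 17-fold higher number from compound 1 to compound 2 (1.25 log units; beyond the scatter), large and beyond the scatter. That step introduced the isopropylcarbamoyl group, which compound 3 no longer carries, so a large move to a lower number in this assay is expected. Its size is poorly fixed, as the starting point is only a limit and hydroxymethyl has not been measured on this core. The expected change is an at least 6.6-fold lower number from compound 2 to compound 3 (0.82 log units; beyond the scatter). For compound 3 the estimate is 1500 nM, with an expected range of 300 nM to 7000 nM.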

Compound 3, half-maximal inhibitory concentration: > 10000 nM
Compound 3 was reported as a limit; the forecaster's own chance of this, stated with the estimate: 20%; middle value at least 6.6-fold (0.82 log units) from the limit.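

In this assay, on an aromatic carbon para to a large group, hydroxymethyl in place of methoxycarbonyl gives an at least 17-fold higher number from compound 1 to compound 3 (1.25 log units; beyond the scatter), so the loss seen with isopropylcarbamoyl at this position is not particular to that group. Compound 3 gives > 10000 nM, which is a limit of the assay and not a number. The step from compound 2 to compound 3 cannot be read, so isopropylcarbamoyl and hydroxymethyl remain unordered, and both compounds end at the same limit: the limit of > 10000 nM in this assay, at which 2 of the 3 values shown sit.

Methoxycarbonyl is still the only group here with a readable value, so it remains open whether that activity extends to close relatives such as an ethyl ester or a carboxylic acid. Going by these compounds, how weak compound 2 and compound 3 actually are also remains open.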